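Tolerability of a Varied Side Group in Vero Cells

This account rests on a few compounds, and the source may have more. Where it says the series, first, only, none or still open, it means among the compounds named here.

Compound 1 `COc1ccc2[nH]c(C(=O)N3CC(=O)N(Cc4ccccc4)[C@@H](CCc4ccccc4)C3)cc2c1` was examined in an ADME assay on Vero cells (Chlorocebus sabaeus) for cytotoxicity, with a stated time of 7 days; a lower number here means that less compound is tolerated, a higher number that more compound is tolerated. In this assay compound 1 gives > 30000 nM, which is a limit of the assay rather than a number. A second compound, compound 2 `COc1cccc(CN2C(=O)CN(C(=O)c3cc4cc(OC)ccc4[nH]3)C[C@@H]2CC2CCCCC2)c1`, carries a different side group on the shared core. In this assay compound 2 gives > 10000 nM, again a limit rather than a number. Compound 1 thus stands at the limit of > 30000 nM in this assay, at which 1 of the 2 values shown sits, while the other value shown sits at the limit of > 10000 nM in this assay, at which 1 of the 2 values shown sits; neither pair of values forms a measured step, so nothing about the size of a change can be read from them.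

Compound 3 `COc1ccc2[nH]c(C(=O)N3CC(=O)N(Cc4ccccc4)[C@@H](CN4C(=O)c5ccccc5C4=O)C3)cc2c1` differs from compound 1 in one place: a group of 11 heavy atoms (8 carbon, 1 nitrogen, 2 oxygen; one five-membered non-aromatic ring with 1 hetero atom, one six-membered aromatic ring of carbon only) in place of a group of 7 heavy atoms (7 carbon; one six-membered aromatic ring of carbon only), on a saturated chain carbon bound to a saturated ring carbon. Going by the values given here, since no step between two measured compounds exists here, the effect of this change has to be guessed from the standing of compound 1 alone. Compound 3 is expected to sit at a limit again, so the step of a number no higher from compound 1 to compound 3 (the limit leaves the size open) is expected to be none beyond the scatter. Compound 3 is therefore estimated at 30000 nM, with a range from 10000 nM to 100000 nM.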

Compound 3, half-maximal cytotoxic concentration: 41000 nM
Beside the measured number, compound 3's estimate is 1.4-fold (0.14 log units) below it; the range from low to high includes it.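

Going by these compounds alone, compound 1 has only a limit in this assay, not a number, and no step from compound 1 to compound 3 can be read from this result. The compounds shown leave open whether the group of compound 3, in place of the benzyl, changes the result in this assay at all, and in which direction.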